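From compound 3 to its 3-chlorophenyl analogue

The source may hold more compounds than are shown below. What is called first, only, known or untested is meant among the compounds shown, and "the series" means these compounds.

Measured so far in a functional assay on MCF7 cells (Homo sapiens) for inhibition, read by sulforhodamine B assay (a lower number here means a stronger inhibitor of growth, a higher number a weaker inhibitor of growth), as follows:
- compound 1 `COc1cc(-c2ccc(-c3ccc(-c4nc5cc(C)ccc5[nH]4)cc3)cc2)cc(OC)c1OC` gives 170 nM
- compound 2 `Oc1ccc(-c2ccc(-c3ccc(-c4nc5ccccc5[nH]4)cc3)cc2)cc1` gives 30500 nM
- compound 3 `Oc1cccc2[nH]c(-c3ccc(-c4ccc(-c5ccccc5)cc4)cc3)nc12` gives 2200 nM

Compound 3 (2200 nM) stands in the middle of these three numbers. Compound 1 lies lower and compound 2 lies higher, and both gaps to compound 3 are beyond the scatter.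

Compound 4 `Oc1cccc2[nH]c(-c3ccc(-c4ccc(-c5cccc(Cl)c5)cc4)cc3)nc12` has not been measured. Its difference from compound 3 (chloro in place of hydrogen on an aromatic carbon) is chloro in place of hydrogen on an aromatic carbon, meta to a large group, so that phenyl becomes 3-chlorophenyl.

Among the compounds with values here, no two measured compounds differ in one place only, so the data hold no direct guide to this change. Compound 1 and compound 2 differ from compound 3 in more than one place and show only how widely the numbers spread. The estimate therefore rests on compound 3 (2200 nM) as the closest reference. A small step towards a lower number is expected, not clearly beyond the scatter. The expected step is a 1.5-fold lower number from compound 3 to compound 4 (0.17 log units; within the scatter) in this estimate. For compound 4 the estimated value is 1500 nM and the expected range runs from 500 nM to 5000 nM in this assay once measured.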

Compound 4, concentration for 50% growth inhibition: 3420 nM
Compound 4: middle estimate off by 2.3-fold (0.36 log units), on the low side; the range from low to high includes it.
By their numbers in this assay, from the lowest: compound 1; then compounds 3 and 4 (each within the scatter of the next); then compound 2.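

In this assay, within the data shown here, the series now has its first pair differing in one place, and it gives a 1.6-fold higher number from compound 3 to compound 4 (0.19 log units; within the scatter), so chloro in place of hydrogen on an aromatic carbon, meta to a large group, produces no step that can be told apart from repeat measurements. The earlier compounds shown here differ from one another in more than one place and could say nothing about any single change on this ring, whereas phenyl to 3-chlorophenyl can now be read directly and leaves compound 3 and compound 4 on a par in this assay. No outside measurement bears on this result, so it stands here without an explanation.

As far as these compounds go, a single chloro in a single place does not show how far this ring accepts change in general, and whether an amine or a carboxylic acid in the same place would move the number beyond the scatter remains open. Also open, from the compounds shown here alone, is whether the same chloro change would give a similar step on the core of compound 1 or that of compound 2.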